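A few compounds are considered here, and "the series" means these few. Any claim that something is new, unique, unknown or untested is made for them only; others in the source may bear on it.

Measured compounds in an ADME assay on liver for metabolic stability, with Liver microsome (Rattus norvegicus) as the target, read by LC-MS, using microsomes, with a stated time of 5 h; a higher number here means faster removal of the compound, a lower number slower removal:
- compound 1, `C[C@]1(O)C[C@](c2cccc(C(F)(F)F)c2)([C@H](O)c2ccccn2)C1`, compound 1 gives 66.7 mL/min/kg
- compound 2, `O[C@H](c1ccccn1)[C@]1(c2cccc(C(F)(F)F)c2)C[C@H](O)C1`, compound 2 gives 183 mL/min/kg
- compound 3, `O[C@H](c1ccccn1)[C@]1(c2ccnc(C(F)(F)F)c2)C[C@@H](O)C1`, compound 3 gives 200 mL/min/kg

Compound 4, `C[C@]1(O)C[C@@](c2ccnc(C(F)(F)F)c2)([C@H](O)c2ccccn2)C1`, has not been measured in this assay.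

For the measured compounds named here, the one change that is measured once and now recurs is methyl in place of hydrogen on a saturated ring carbon. In this assay it gave a 2.7-fold lower number from compound 2 to compound 1 (0.44 log units; beyond the scatter), a step beyond the scatter. The change from compound 3 to compound 4 is methyl in place of hydrogen on a saturated ring carbon, and its place line matches the earlier one word for word, so it is the same change on a different core. How the core of compound 3 differs from that of compound 2 is not broken down here; their two values in this assay lie within the scatter of each other, so nothing can be said of an order between compound 2 and compound 3.

Going by the values given here, with only one prior instance of the change, the expectation for compound 4 rests on that single step. Because compound 3 gives 200 mL/min/kg and the earlier methyl step gave a 2.7-fold lower number from compound 2 to compound 1 (0.44 log units; beyond the scatter), compound 4 is expected to show a step of a 2.7-fold lower number from compound 3 to compound 4 (0.43 log units; beyond the scatter) in this assay. Compound 4 is therefore estimated at 75 mL/min/kg in this assay, with a likely span from 40 mL/min/kg to 140 mL/min/kg. The width reflects that the transfer of one step from one core to another is uncertain, and any further instances of the change would tighten or overturn this.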

Compound 4, clearance: 50 mL/min/kg
Compound 4: the middle estimate sits 1.5-fold (0.18 log units) above what was measured; the range from low to high includes it.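

In this assay, methyl in place of hydrogen on a saturated ring carbon gives a 4.0-fold lower number from compound 3 to compound 4 (0.60 log units; beyond the scatter), and this new step runs in the same direction as the earlier one on the other core. Set side by side, the two steps show no difference that can be told from the usual scatter: the same change on two cores in this assay, a 2.7-fold lower number (0.44 log units; beyond the scatter) from compound 2 to compound 1 and a 4.0-fold lower number (0.60 log units; beyond the scatter) from compound 3 to compound 4, 1.5-fold (0.16 log units) apart, within the scatter of two such steps. The change therefore carried from the core of compound 2 to the core of compound 3 with its direction and its size preserved in this assay, but this rests on two pairs alone, says nothing about any other core in the series, and gives no cause for the lower number.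

The compounds shown leave open whether a different group on the same saturated ring carbon, such as an ethyl group or a fluorine atom, would give a step like that of methyl. Also open, going by these compounds, is whether the methyl step would hold once the hydroxy(pyridin-2-yl)methyl group is replaced, for instance by a longer chain carrying an amine, and whether it would appear at all in another assay.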